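Swapping the azepane for a methylpyrrolidine

The compounds below may be only part of what the source reports. "The series", "measured", "known", "first", "only" and "open" are said of these compounds alone.

Three compounds have been measured in an assay on isolated protein for displacement of a labelled ligand from melanin-concentrating hormone receptor 1 (Homo sapiens); a lower number here means a stronger inhibitor, a higher number a weaker inhibitor:
Compound 1, `NC1CCN(c2ccc3cc(NC(=O)CCc4ccc(C(F)(F)F)cc4)ccc3n2)C1`, gives 12 nM.
Compound 2, `O=C(CCc1ccc(C(F)(F)F)cc1)Nc1ccc2nc(N3CCCCCC3)ccc2c1`, gives 36 nM.
Compound 3, `CC(=O)NC1CCN(c2ccc3cc(NC(=O)CCc4ccc(C(F)(F)F)cc4)ccc3n2)C1`, gives 5 nM.

Compound 2 carries the highest number of the three; the steps of a 3.0-fold higher number from compound 1 to compound 2 (0.48 log units; beyond the scatter) and a 7.2-fold lower number from compound 2 to compound 3 (0.86 log units; beyond the scatter) both lie beyond the scatter. Compound 4, `CC1CCN(c2ccc3cc(NC(=O)CCc4ccc(C(F)(F)F)cc4)ccc3n2)C1`, differs from compound 2 by 3-methylpyrrolidin-1-yl in place of azepan-1-yl on an aromatic carbon. Among the compounds with values here, both measured replacements of the azepane by a pyrrolidine lowered the number, yet those pyrrolidines carried an amine or acetamide, and the step of a 2.4-fold lower number from compound 1 to compound 3 (0.38 log units; beyond the scatter) shows that substituent matters; the methyl has no counterpart among measured compounds. A modest lowering is therefore expected, a 1.8-fold lower number from compound 2 to compound 4 (0.26 log units; within the scatter), within the range of the measured pyrrolidines. Compound 4 is estimated at 20 nM, between 8 nM and 50 nM.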

Compound 4, half-maximal inhibitory concentration: 2 nM
Compound 4: middle estimate off by 10-fold (1.00 log units), on the high side, outside the stated range (below it).
By their numbers in this assay, from the lowest: compound 4; then compound 3; then compound 1; then compound 2.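

The azepane-to-methylpyrrolidine change gives the largest step yet at this position, an 18-fold lower number from compound 2 to compound 4 (1.26 log units; beyond the scatter), and the methyl also outperforms both substituted pyrrolidines measured earlier. Replacing amino with methyl gives a 6.0-fold lower number from compound 1 to compound 4 (0.78 log units; beyond the scatter), and replacing acetamido with methyl gives a 2.5-fold lower number from compound 3 to compound 4 (0.40 log units; beyond the scatter), so neither group is needed on this ring for a low number. Nothing available explains this gain. On these data alone, it remains open whether an unsubstituted pyrrolidine, or an ethyl or hydroxyl group on the same ring carbon, would keep the number this low.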